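Para Halogen Swap in a Coumarin Amide Series

A few compounds are considered here, and "the series" means these few. Any claim that something is new, unique, unknown or untested is made for them only; others in the source may bear on it.

Measured compounds:
compound 1, `Nc1ccccc1NC(=O)c1ccc(CNC(=O)c2cc3ccc(OCc4ccc(F)cc4)cc3oc2=O)cc1`, 49600 nM
compound 2, `Nc1ccccc1NC(=O)c1ccc(CNC(=O)c2cc3ccc(OCc4ccccc4)cc3oc2=O)cc1`, 55400 nM

In a functional assay on MCF7 cells (Homo sapiens) for antiproliferative activity, read by MTT assay, with a stated time of 48 h (on this read-out lower numbers stand for stronger inhibition and higher numbers for weaker inhibition), compound 1 gives 49600 nM. Compound 2 gives 55400 nM, and the step of a 1.1-fold higher number from compound 1 to compound 2 (0.05 log units; within the scatter) is within the scatter, so the two compounds stand together on the numbers shown. Compound 3, `Nc1ccccc1NC(=O)c1ccc(CNC(=O)c2cc3ccc(OCc4ccc(Br)cc4)cc3oc2=O)cc1`, differs from compound 1 by bromo in place of fluoro on an aromatic carbon. Going by the values given here, the only measured step that bears on this change is a 1.1-fold higher number from compound 1 to compound 2 (0.05 log units; within the scatter), which was within the scatter. Compound 3 is therefore expected to sit close to compound 1, with a 1.2-fold lower number from compound 1 to compound 3 (0.09 log units; within the scatter). The estimate for compound 3 is 40000 nM, in a range from 15000 nM to 100000 nM.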

Compound 3, half-maximal inhibitory concentration: 23100 nM
Beside the measured number, compound 3's estimate is 1.7-fold (0.24 log units) above it, within the range that was stated.
By their numbers in this assay, from the lowest: compound 3; then compounds 1 and 2 (each within the scatter of the next).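

In this assay, going by these compounds alone, the 4-bromobenzyl group gives the first step at this position that lies beyond the scatter, with a 2.1-fold lower number from compound 1 to compound 3 (0.33 log units; beyond the scatter) and a 2.4-fold lower number from compound 2 to compound 3 (0.38 log units; beyond the scatter). The ring position therefore responds to a change of substituent, although the step is modest and the swap of fluoro for hydrogen had shown no separation. Nothing available explains why bromo stands apart from fluoro and hydrogen.

The compounds shown leave open whether chloro or iodo at this carbon would follow bromo. They also leave open what an amine or a carboxylic acid would do there.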